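Amide aryl variation in a sulfonamide series: compound 4

The source may report more compounds than this note shows. Statements on the series, on what has been measured and on what is new or still open speak of the compounds shown alone.

Measured in an assay on isolated protein for displacement of a labelled ligand from secreted frizzled-related protein 1 (Homo sapiens), read by fluorescence polarization, with a stated time of 30 min; on this read-out lower numbers stand for stronger inhibition and higher numbers for weaker inhibition: compound 1 `O=C(c1cccc(Cl)c1)N1CCC(NS(=O)(=O)c2cc(S(=O)(=O)c3ccccc3)ccc2C(F)(F)F)CC1` gives 300 nM; compound 2 `O=C(c1ccc(Cl)cc1)N1CCC(NS(=O)(=O)c2cc(S(=O)(=O)c3ccccc3)ccc2C(F)(F)F)CC1` gives 300 nM; compound 3 `O=C(c1ccc(C(F)(F)F)cc1)N1CCC(NS(=O)(=O)c2cc(S(=O)(=O)c3ccccc3)ccc2C(F)(F)F)CC1` gives 400 nM.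

Compound 3 holds the highest of the three numbers, yet it sits within the scatter of both neighbours: a 1.3-fold higher number from compound 1 to compound 3 (0.12 log units; within the scatter) and a 1.3-fold higher number from compound 2 to compound 3 (0.12 log units; within the scatter). Compound 4 `CN(C)c1ccc(C(=O)N2CCC(NS(=O)(=O)c3cc(S(=O)(=O)c4ccccc4)ccc3C(F)(F)F)CC2)cn1` carries 6-(dimethylamino)pyridin-3-yl in place of 4-(trifluoromethyl)phenyl on a carbonyl carbon. Every step measured so far exchanges one substituent on the aryl amide and none moves beyond the scatter, including no change at the digits printed from compound 1 to compound 2 (within the scatter). Going by the values given here, no measured step covers a ring nitrogen or a dimethylamino group, so nothing speaks directly for compound 4. The working expectation in this assay is therefore a step of about no change at the digits printed from compound 3 to compound 4 (within the scatter), not beyond the scatter. Compound 4 is estimated at 400 nM, with a range from 150 nM to 1100 nM.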

Compound 4, half-maximal inhibitory concentration: 40 nM
The estimate for compound 4 lay 10-fold (1.00 log units) above the measured number; measured number below the stated range.
By their numbers in this assay, from the lowest: compound 4; then compounds 1, 2 and 3 (each within the scatter of the next).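

Exchanges among the chlorophenyl and 4-(trifluoromethyl)phenyl groups stayed within the scatter, but 6-(dimethylamino)pyridin-3-yl on this carbonyl carbon moves the number beyond it in this assay with a 10-fold lower number from compound 3 to compound 4 (1.00 log units; beyond the scatter) and a 7.5-fold lower number from compound 2 to compound 4 (0.88 log units; beyond the scatter) and a 7.5-fold lower number from compound 1 to compound 4 (0.88 log units; beyond the scatter). The change brings in the ring nitrogen and the dimethylamino group together, so the step cannot be divided between them. No measured evidence bears on the origin of this step.

Still open, as far as these compounds go, is whether plain pyridin-3-yl or 4-(dimethylamino)phenyl alone keeps the lower number. Also open, from the compounds shown here alone, is how a morpholine or pyrrolidine would compare with the dimethylamino group.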